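This account rests on a few compounds, and the source may have more. Where it says the series, first, only, none or still open, it means among the compounds named here.

In a functional assay on HT cells (Homo sapiens) for antiproliferative activity, read by fluorescence, with a stated time of 72 h (on this read-out lower numbers stand for stronger inhibition of growth and higher numbers for weaker inhibition of growth), compound 1 `CC(O)CSc1nc(NCc2ccc(-c3ccccn3)cc2)c2[nH]nc(C(C)C)c2n1` gives 62 nM and compound 2 `CC(C)c1n[nH]c2c(NCc3ccc(-c4ccccn4)cc3)nc(SC(CO)C(C)C)nc12` gives 980 nM while compound 3 `CC(C)c1n[nH]c2c(NCc3ccc(-c4ccccn4)cc3)nc(SCCN)nc12` gives 22 nM as the lowest number of the three. Compound 4 `CC(C)c1n[nH]c2c(NCc3ccc(-c4ccccn4)cc3)nc(SCCC(N)=O)nc12` has carbamoyl in place of amino on a saturated chain carbon, two bonds along the chain from a sulfur, with carbamoyl in place of amino on a saturated chain carbon, two bonds along the chain from a sulfur as the count of that difference. Among the measured compounds shown here, no measured step makes this exact change. The closest is a 2.8-fold lower number from compound 1 to compound 3 (0.45 log units; beyond the scatter) and it was modest, replacing 1-hydroxyethyl with aminomethyl. The large steps of a 16-fold higher number from compound 1 to compound 2 (1.20 log units; beyond the scatter) and a 45-fold lower number from compound 2 to compound 3 (1.65 log units; beyond the scatter) both turn on the 1-(hydroxymethyl)-2-methylpropyl group, which compound 4 lacks. A modest rise in the number is therefore expected, and a 3.2-fold higher number from compound 3 to compound 4 (0.50 log units; beyond the scatter) is the estimated step in this assay terms. Compound 4 is estimated at 70 nM within an expected range from 20 nM to 250 nM on this measure.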

Compound 4, concentration for 50% growth inhibition: 120 nM
For compound 4 the middle estimate is 1.7-fold (0.23 log units) below the measured one; the range from low to high includes it.
By their numbers in this assay, from the lowest: compound 3; then compounds 1 and 4 (each within the scatter of the next); then compound 2.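

In this assay, carbamoyl in place of amino on this chain weakens growth inhibition (a 5.5-fold higher number from compound 3 to compound 4 (0.74 log units; beyond the scatter)), so the amino group of compound 3 is not matched by this longer neutral-count replacement. The 2-carbamoylethyl group still far outperforms the branched chain of compound 2 (an 8.2-fold lower number from compound 2 to compound 4 (0.91 log units; beyond the scatter)) and stands level with the 2-hydroxypropyl group of compound 1 (a 1.9-fold higher number from compound 1 to compound 4 (0.29 log units; within the scatter)). Nothing measured here accounts for these shifts.

The compounds shown leave open how a carboxylic acid in place of the carbamoyl, or a longer chain ending in an amine, would compare with compound 3.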